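Cytotoxicity notes on a quinoline-diamine series: compound 2 to 4

The source may report more compounds than this note shows. Statements on the series, on what has been measured and on what is new or still open speak of the compounds shown alone.

Measured so far in an ADME assay on HepG2 cells (Homo sapiens) for cytotoxicity, read by luminescence, CellTiter-Glo and ATP content, with a stated time of 72 h; on this read-out lower numbers stand for an effect already at smaller amounts and higher numbers for an effect only at larger amounts of compound:
- compound 1 `COc1ccc(-c2ccc3c(NCCCNCc4cccc(OC)c4O)ccnc3c2)cc1`: 1600 nM
- compound 2 `c1ccc(CCc2ccc3c(NCCCNCc4ccco4)ccnc3c2)cc1`: 16000 nM
- compound 3 `CCC(CC)c1ccc2c(NCCCNCc3cc(F)ccc3OC)ccnc2c1`: 7860 nM

Compound 2 stands at the highest number of the three; its nearest neighbour is compound 3, whose number lies lower by a gap beyond the scatter, and compound 1 lies furthest, lower by a gap well beyond the scatter. No pair of these compounds differs in only one place, so no single step among the measured compounds can be read off.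

Compound 4 `COc1ccccc1Oc1ccc2c(NCCCNCc3ccco3)ccnc2c1` is not yet measured. Its difference from compound 2 is 2-methoxyphenoxy in place of phenethyl on an aromatic carbon.

For the measured compounds named here, with no matching step available, the expectation for compound 4 rests on the spread of the three numbers. A modest move to a lower number is expected, a 2.0-fold lower number from compound 2 to compound 4 (0.30 log units; within the scatter), with a wide range. Compound 4 is estimated at 8000 nM in this assay, between 2500 nM and 25000 nM.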

Compound 4, half-maximal effective concentration: 6500 nM
Compound 4: the middle estimate sits 1.2-fold (0.09 log units) above what was measured, and the stated range covers the measured number.
By their numbers in this assay, from the lowest: compound 1; then compounds 4 and 3 (each within the scatter of the next); then compound 2.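

For the compounds shown here, this is the first step that can be read at a single place: in this assay, 2-methoxyphenoxy in place of phenethyl on an aromatic carbon of the shared core gives a 2.5-fold lower number from compound 2 to compound 4 (0.39 log units; beyond the scatter) and counts as a modest change. The number at this position therefore moves, though not far, when an oxygen-linked aryl group carrying hydrogen-bond acceptors replaces a carbon-only chain with none. Nothing available here bears on what lies behind the step.

Going by these compounds, whether this exchange gives a step of similar size with the side chains of compound 1 or compound 3 stays open. Also open, on these data alone, is how this position would read with a simple amine, a carboxylic acid or a longer alkyl chain.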